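Chloro for Fluoro on a Nucleotide Agonist

This account rests on a few compounds, and the source may have more. Where it says the series, first, only, none or still open, it means among the compounds named here.

Measured compounds:
Compound 1, `Cc1ccc2c(=O)n([C@@H]3O[C@H](COP(=O)(O)OP(=O)(O)OP(=O)(O)O)[C@@H](O)[C@H]3O)ccc2c1`: 35 nM
Compound 2, `O=c1c2ccc(F)cc2ccn1[C@@H]1O[C@H](COP(=O)(O)OP(=O)(O)OP(=O)(O)O)[C@@H](O)[C@H]1O`: 77 nM

Both compounds were tested in a functional assay for agonist activity at P2Y purinoceptor 2 (Homo sapiens), read by FLIPR; on this read-out higher numbers stand for an effect only at larger amounts of compound and lower numbers for an effect already at smaller amounts. Among the two numbers that exist, compound 2 has the higher one; its only neighbour is compound 1, and the one measured step, a 2.2-fold higher number from compound 1 to compound 2 (0.34 log units; beyond the scatter), is a modest shift that lies beyond the usual scatter.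

Compound 3, `O=c1c2ccc(Cl)cc2ccn1[C@@H]1O[C@H](COP(=O)(O)OP(=O)(O)OP(=O)(O)O)[C@@H](O)[C@H]1O`, has not yet been measured in this assay. It differs from compound 2 in one place: chloro in place of fluoro on an aromatic carbon. Among the compounds with values here, the only measured step that bears on this position is the one from methyl to fluoro, a 2.2-fold higher number from compound 1 to compound 2 (0.34 log units; beyond the scatter), which shows that a change at this carbon can move the number by a modest amount. Within the data shown here, no measured pair shows chloro directly, so the direction for compound 3 rests on that single step alone.

For compound 3, a number close to those already seen is expected in this assay, with the estimated step of a 1.4-fold lower number from compound 2 to compound 3 (0.15 log units; within the scatter), which would fall within the scatter. The estimate for compound 3 is 55 nM, with a range from 22 nM to 140 nM.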

Compound 3, half-maximal effective concentration: 541 nM
Beside the measured number, compound 3's estimate is 9.8-fold (0.99 log units) below it, outside the stated range (above it).
By their numbers in this assay, from the lowest: compound 1; then compound 2; then compound 3.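

In this assay, this aromatic carbon turns out to be far more sensitive than the first pair suggested: chloro in place of fluoro gives a 7.0-fold higher number from compound 2 to compound 3 (0.85 log units; beyond the scatter), a larger move than the earlier 2.2-fold higher number from compound 1 to compound 2 (0.34 log units; beyond the scatter). The swap is small on paper, since one heavy atom leaves, one enters, and the computed counts of rings, hydrogen-bond donors, hydrogen-bond acceptors and net charge stay the same, so those counts do not separate the two groups even though the numbers differ clearly. Set against methyl, chloro gives a 15-fold higher number from compound 1 to compound 3 (1.19 log units; beyond the scatter), which makes it the group with the highest number of the three, and it shows that one halogen at this carbon does not predict the other.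

Nothing measured here accounts for the size of this jump. The three compounds also leave open whether bromo, methoxy, an amine or a longer chain such as ethyl at this same carbon would stay near compound 1 or move towards compound 3, and only such further groups could show whether chloro is an isolated case or part of a wider trend.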